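Methoxyphenyl position shift on the shared core

The source may report more compounds than this note shows. Statements on the series, on what has been measured and on what is new or still open speak of the compounds shown alone.

Measured compounds:
compound 1 `CC(C)(C)c1cc2nn(-c3ccccc3)c(N)c2c(=O)[nH]1` — -1%
compound 2 `Nc1c2c(=O)[nH]c(-c3ccccn3)cc2nn1-c1ccccc1` — 3%
compound 3 `COc1ccccc1-c1cc2nn(-c3ccccc3)c(N)c2c(=O)[nH]1` — 4%

In an assay on isolated protein for inhibition of protein kinase C zeta type (Homo sapiens), read by mobility shift assay, tested at 30 uM (a higher number here means more inhibition at the concentration tested (going by the name of the read-out), a lower number less inhibition), compound 3 gives the largest of the three numbers, but the steps of a number 1 percentage points higher from compound 2 to compound 3 (within the scatter) and a number 5 percentage points higher from compound 1 to compound 3 (within the scatter) both lie within the scatter, so the three compounds do not separate. Compound 4 `COc1ccc(-c2cc3nn(-c4ccccc4)c(N)c3c(=O)[nH]2)cc1` differs from compound 3 by 4-methoxyphenyl in place of 2-methoxyphenyl on an aromatic carbon. Every measured step changes the group at this same place: a number 4 percentage points higher from compound 1 to compound 2 (within the scatter), a number 5 percentage points higher from compound 1 to compound 3 (within the scatter), a number 1 percentage points higher from compound 2 to compound 3 (within the scatter), all within the scatter and all near zero. No step beyond the scatter is therefore expected for the move from compound 3 to compound 4, a number 1 percentage points lower from compound 3 to compound 4 (within the scatter). Compound 4 is estimated at 3%, with a range from -8% to 14%.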

Compound 4, a percentage reported as inhibition, at one concentration (the size of the read-out at that concentration, not a potency): 0%
Estimate against measurement, compound 4: 3 percentage points above; the range from low to high includes it.
By their numbers in this assay, from the lowest: compounds 1, 4, 2 and 3 (each within the scatter of the next).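

In this assay, 4-methoxyphenyl in place of 2-methoxyphenyl gives a number 4 percentage points lower from compound 3 to compound 4 (within the scatter), so the two methoxyphenyl arrangements on this aromatic carbon do not separate. The further comparisons, a number 3 percentage points lower from compound 2 to compound 4 (within the scatter) and a number 1 percentage points higher from compound 1 to compound 4 (within the scatter), place 4-methoxyphenyl within the scatter of pyridin-2-yl and tert-butyl as well, so none of the four groups at this place stands apart from the others. No supporting evidence bears on this result.

Going by these compounds, whether an amine, a carboxylic acid or a longer chain at this place would give a number clear of the scatter remains open. Also open, on these data alone, is whether a change elsewhere on the shared core would do so.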